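Cytotoxicity of the benzyl series on Huh-7 cells

A few compounds are considered here, and "the series" means these few. Any claim that something is new, unique, unknown or untested is made for them only; others in the source may bear on it.

Working notes on the series. Compound 1 `CS(=O)(=O)Nc1ccc2c(c1)S(=O)(=O)N=C(C1=C(O)C3CCCC3N(Cc3ccc(Cl)cc3)C1=O)N2` has only a limit in an ADME assay on Huh-7 cells (Homo sapiens) for cytotoxicity, with a stated time of 72 h; a higher number here means that more compound is tolerated, a lower number that less compound is tolerated: compound 1 gives > 10000 nM, which is a limit of the assay. Compound 2 `CS(=O)(=O)Nc1ccc2c(c1)S(=O)(=O)N=C(C1=C(O)C3CCCCC3N(C3CCCCC3)C1=O)N2` likewise gives > 33000 nM in this assay, again a limit. Both values shown for this assay are limits (the limit of > 10000 nM in this assay, at which 1 of the 2 values shown sits, (the limit of > 33000 nM in this assay, at which 1 of the 2 values shown sits)), so compound 1 cannot be placed within them. Compound 3 `CS(=O)(=O)Nc1ccc2c(c1)S(=O)(=O)N=C(C1=C(O)C3CCCC3N(Cc3cccc(F)c3)C1=O)N2` differs from compound 1 by 3-fluorophenyl in place of 4-chlorophenyl on a saturated chain carbon bound to an amide-type nitrogen in a ring. Within the data shown here, no step in this assay is known, and no step beyond the scatter is expected, with the step from compound 1 to compound 3 estimated as a step that the limit leaves unreadable from compound 1 to compound 3. Compound 3 is therefore expected at 20000 nM, in the range 8000 nM to 60000 nM.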

Compound 3, half-maximal cytotoxic concentration: > 33000 nM
Compound 3: only a limit was reported; the forecaster's own chance of this, stated with the estimate: 80%; middle value at least 1.6-fold (0.21 log units) away from the limit.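

Among these compounds, compound 1 and compound 3 both stand as limits in this assay, so no step between them can be read. The compounds shown leave open whether 3-fluorophenyl in place of 4-chlorophenyl shifts the half-maximal cytotoxic concentration at all.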